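Isopropyl for Isobutyl on the Carbonyl Carbon

This account rests on a few compounds, and the source may have more. Where it says the series, first, only, none or still open, it means among the compounds named here.

Measured compounds:
compound 1, `Cc1cccc(Cn2c(CN3CCN(C(=O)CC(C)C)CC3)nc3ccccc32)c1`: 71.4%
compound 2, `O=C(C1CC1)N1CCN(Cc2nc3ccccc3n2Cc2ccc(C(F)(F)F)cc2)CC1`: 37%

Of the compounds shown here, two have been measured in an assay on isolated protein for inhibition of aldehyde dehydrogenase 1A1 (Homo sapiens), read by spectrophotometry, tested at 10 uM; a higher number here means more inhibition at the concentration tested (going by the name of the read-out), a lower number less inhibition. In this assay compound 1 gives 71.4%, and compound 2 gives 37%. Compound 1 stands highest of the two numbers; its nearest neighbour, compound 2, lies lower by a gap beyond the usual scatter. Compound 1 and compound 2 differ from each other in more than one place, so the two values show no single isolated change.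

Compound 3, `Cc1cccc(Cn2c(CN3CCN(C(=O)C(C)C)CC3)nc3ccccc32)c1`, differs from compound 1 in one place only: isopropyl in place of isobutyl on a carbonyl carbon. Going by the values given here, no measured pair shows this change, so there is no step to lean on; the new substituent is one carbon smaller, otherwise alike in its counted features. The step of a number 8.4 percentage points lower from compound 1 to compound 3 (within the scatter) is expected to be small, probably within the scatter, with a slight lean downward. Compound 3 is therefore estimated at 63% in this assay, with a range from 42% to 80%.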

Compound 3, a percentage reported as inhibition, at one concentration (the size of the read-out at that concentration, not a potency): 87.2%
Compound 3: middle estimate off by 24.2 percentage points, on the low side; the measured number lies above the stated range.
By their numbers in this assay, from the lowest: compound 2; then compound 1; then compound 3.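

In this assay, the carbonyl carbon whose other neighbour is the amide-type nitrogen in a ring turns out to respond to a small change in its substituent: isopropyl in place of isobutyl gives a number 15.8 percentage points higher from compound 1 to compound 3 (beyond the scatter). Going by these compounds alone, this is the first single-place change, since compound 1 and compound 2 differ in more than one place and could not isolate any one group. Neither of the swapped groups has a ring, a hydrogen-bond donor, a hydrogen-bond acceptor or a net charge, and nothing available explains the direction or size of the step.

The compounds shown leave open whether an ethyl or a tert-butyl on the same carbonyl carbon would raise the inhibition further or lower it, as a single step cannot describe a trend at this position. They also leave open whether isopropyl in place of isobutyl would give a similar step on a different background, such as one carrying the trifluoromethyl group of compound 2.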